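Trimming the Hydroxyethyl Sulfone to an Ethyl Sulfone

The compounds below may be only part of what the source reports. "The series", "measured", "known", "first", "only" and "open" are said of these compounds alone.

Among the measured compounds shown here, compound 2 `Cc1ccc(S(=O)(=O)CCO)cc1C#Cc1cc(Cl)ccc1OCC(=O)O` gives 19 nM in an assay on CHO cells for displacement of a labelled ligand from prostaglandin D2 receptor 2 (Homo sapiens), read by scintillation counting (on this read-out higher numbers stand for weaker inhibition and lower numbers for stronger inhibition), the higher of the two numbers measured so far. For the measured compounds named here, compound 1 `COCCN(C)S(=O)(=O)c1ccc(C)c(C#Cc2cc(Cl)ccc2OCC(=O)O)c1` gives 4.1 nM in this assay; the only measured step, a 4.6-fold higher number from compound 1 to compound 2 (0.67 log units; beyond the scatter), exchanged the whole group on the sulfonyl sulfur. Compound 3 `CCS(=O)(=O)c1ccc(C)c(C#Cc2cc(Cl)ccc2OCC(=O)O)c1` differs from compound 2 by hydrogen in place of hydroxy on a saturated chain carbon, two bonds along the chain from a sulfonyl sulfur. Going by the values given here, no measured step removes a hydroxy on its own, so the direction is uncertain; that compound 1, also without a hydroxy, gives 4.1 nM hints weakly at some gain. Compound 3 is therefore expected to show a modest step, a 1.6-fold lower number from compound 2 to compound 3 (0.20 log units; within the scatter), with an estimated 12 nM and a range from 4 nM to 35 nM.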

Compound 3, inhibition constant: 8.6 nM
Compound 3: middle estimate off by 1.4-fold (0.14 log units), on the high side; the measured number falls inside the stated range.
By their numbers in this assay, from the lowest: compound 1; then compound 3; then compound 2.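

Taking the hydroxy away on its own gives a 2.2-fold lower number from compound 2 to compound 3 (0.34 log units; beyond the scatter) in this assay, so the hydroxy of the 2-hydroxyethyl group is not needed for binding here, and the plain ethyl sulfone does better. Even so, ethyl does not match the (2-methoxyethyl)(methyl)amino group on the sulfonyl sulfur, with a 2.1-fold higher number from compound 1 to compound 3 (0.32 log units; beyond the scatter). Nothing measured here explains either step. Still open, going by these compounds, is whether a longer chain, or an amine or carboxylic acid at the end of the ethyl group, would lower the number further.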